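Replacing Fluoro with 4-Fluorophenyl: From Compound 1 to Compound 4

The source may hold more compounds than are shown below. What is called first, only, known or untested is meant among the compounds shown, and "the series" means these compounds.

Measured compounds:
- Compound 1, `Cc1cc(F)c(S(C)(=O)=O)cc1C(=O)N=C(N)N`, gives 44 nM in a functional assay for inhibition of sodium/hydrogen exchanger (Oryctolagus cuniculus); on this read-out lower numbers stand for stronger inhibition and higher numbers for weaker inhibition.
- Compound 3, `Cc1cc(-c2ccc(Cl)cc2Cl)c(S(C)(=O)=O)cc1C(=O)N=C(N)N`, gives 42 nM.
- Compound 2, `Cc1c(C(=O)N=C(N)N)ccc(Cl)c1S(C)(=O)=O`, gives 1300 nM.

Among these three numbers compound 1 stands second highest. Its nearest neighbour is compound 3, whose value sits within the scatter of compound 1; the furthest is compound 2, whose number is beyond the scatter, so compound 2 is clearly the weaker inhibitor of the three.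

The unmeasured compound 4, `Cc1cc(-c2ccc(F)cc2)c(S(C)(=O)=O)cc1C(=O)N=C(N)N`, is built from compound 1 by a single change: 4-fluorophenyl in place of fluoro on an aromatic carbon

Among the measured compounds shown here, one measured step bears directly on this. Between compound 1 and compound 3, 2,4-dichlorophenyl took the place of fluoro on the same aromatic carbon, and the result was a 1.0-fold lower number from compound 1 to compound 3 (0.02 log units; within the scatter). That step shows a large group in place of fluoro at this position leaving the number essentially unchanged. The change to compound 4 puts a smaller, similar group in the same place, so no step beyond the scatter is expected in this assay.

Compound 4 is therefore expected to give about 45 nM, within a range of 20 nM to 110 nM, a step of a 1.0-fold higher number from compound 1 to compound 4 (0.01 log units; within the scatter) that is expected to stay within the scatter.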

Compound 4, half-maximal inhibitory concentration: 36 nM
Compound 4: middle estimate off by 1.3-fold (0.10 log units), on the high side; low and high end bracket the measured number.
By their numbers in this assay, from the lowest: compounds 4, 3 and 1 (each within the scatter of the next); then compound 2.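

In this assay, putting 4-fluorophenyl in place of fluoro gives a 1.2-fold lower number from compound 1 to compound 4 (0.09 log units; within the scatter), so this second ring-bearing group also leaves the number level with that of the small fluoro group. Exchanging one ring-bearing group for the other gives a 1.2-fold lower number from compound 3 to compound 4 (0.07 log units; within the scatter), which shows that neither the two chlorine atoms of 2,4-dichlorophenyl nor their placement on that ring is needed to keep the number at this level, as 4-fluorophenyl serves equally well on the carbon ortho to the methylsulfonyl group. Fluoro, 4-fluorophenyl and 2,4-dichlorophenyl thus form a set of three quite different groups at this one place with no separation among their numbers, but the data at hand offer nothing that explains this.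

All of the groups shown at this place carry fluorine or chlorine, so the compounds leave open whether a plain phenyl ring, an amine such as dimethylamino, a carboxylic acid or a longer chain such as n-butyl would hold the number as well. They also leave open which group, if any, at this place would move the number beyond the scatter in either direction.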